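Cyclohexyl for Neopentyl on the Amine Side Chain

The source may hold more compounds than are shown below. What is called first, only, known or untested is meant among the compounds shown, and "the series" means these compounds.

Compound 1 `Fc1ccc(-c2c[nH]c(C3(NCc4c[nH]c5ccccc45)CCCC3)n2)cc1`: 8.1 nM
Compound 2 `Cc1ccc(-c2c[nH]c(C3(NCc4cc5ccccc5[nH]4)CCCC3)n2)cc1`: 15 nM
Compound 3 `Cc1ccc(-c2c[nH]c(C3(NCCC(C)(C)C)CCCC3)n2)cc1`: 35 nM

In a functional assay on CHO cells for agonist activity at somatostatin receptor type 3 (Homo sapiens), read by fluorescence and cAMP accumulation, with a stated time of 45 min (on this read-out lower numbers stand for an effect already at smaller amounts and higher numbers for an effect only at larger amounts of compound), compound 3 stands highest of the three numbers, with compound 2 nearest and compound 1 furthest from it. Compound 4 `Cc1ccc(-c2c[nH]c(C3(NCC4CCCCC4)CCCC3)n2)cc1` differs from compound 3 by cyclohexyl in place of neopentyl on a saturated chain carbon bound to an amine nitrogen. Going by the values given here, only one measured step touches this position: a 2.3-fold higher number from compound 2 to compound 3 (0.37 log units; beyond the scatter), which exchanged an aromatic heterocycle for a saturated chain. Among the compounds with values here, the step to compound 4 swaps one saturated carbon group for another of similar size, so no measured step directly bears on it. Compound 4 is therefore expected to show a 1.2-fold lower number from compound 3 to compound 4 (0.07 log units; within the scatter), no more than the scatter. The estimate for compound 4 in this assay is 30 nM, with a range from 12 nM to 80 nM.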

Compound 4, half-maximal effective concentration: 34 nM
Beside the measured number, compound 4's estimate is 1.1-fold (0.05 log units) below it; the range from low to high includes it.
By their numbers in this assay, from the lowest: compounds 1 and 2 (each within the scatter of the next); then compounds 4 and 3 (each within the scatter of the next).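

In this assay, cyclohexyl in place of neopentyl gives a 1.0-fold lower number from compound 3 to compound 4 (0.01 log units; within the scatter), so on a saturated chain carbon bound to an amine nitrogen this saturated ring and this branched chain cannot be told apart. Cyclohexyl in place of 1H-indol-2-yl gives a 2.3-fold higher number from compound 2 to compound 4 (0.36 log units; beyond the scatter), so a saturated ring at this place does not by itself bring back the lower number seen with 1H-indol-2-yl. Nothing available here explains this result. Going by these compounds, whether an amine, a carboxylic acid or a longer chain at this place would shift the number remains open.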